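Amide versus urea linkers in the pyrazole series

The compounds below may be only part of what the source reports. "The series", "measured", "known", "first", "only" and "open" are said of these compounds alone.

Measured compounds:
- compound 1 `COc1cc(-c2nn(-c3cccc(NC(=O)Nc4cc(C(F)(F)F)cc(C(F)(F)F)c4)c3)cc2-c2ccncc2)ccc1Cl` — 410 nM
- compound 2 `COc1cc(-c2nn(-c3cccc(NC(=O)c4cccc(C(F)(F)F)c4)c3)cc2-c2ccncc2)ccc1Cl` — 1200 nM
- compound 3 `O=C(Nc1cccc(-n2cc(-c3ccncc3)c(-c3ccc(Cl)c(O)c3)n2)c1)Nc1cc(C(F)(F)F)cc(C(F)(F)F)c1` — 400 nM

In a functional assay on OVCAR-3 cells (Homo sapiens) for inhibition, read by sulforhodamine B assay, with a stated time of 48 h (a lower number here means a stronger inhibitor, a higher number a weaker inhibitor), compound 2 gives 1200 nM, the highest number of the three; compound 1 and compound 3 both sit beyond the scatter below it. Compound 4 `COc1cc(-c2nn(-c3cccc(NC(=O)Nc4ccc(Cl)c(C(F)(F)F)c4)c3)cc2-c2ccncc2)ccc1Cl` has not been measured. It differs from compound 2 by (4-chloro-3-(trifluoromethyl)phenyl)amino in place of 3-(trifluoromethyl)phenyl on a carbonyl carbon, which turns the amide of compound 2 into a urea of the kind carried by compound 1 and compound 3. Within the data shown here, the only single-point step on record, a 1.0-fold lower number from compound 1 to compound 3 (0.01 log units; within the scatter), concerns the methoxy and not the linker, so it bears only indirectly. The gap between compound 2 and compound 1, however, shows what accompanies the amide-to-urea change alongside a change of the aryl group, and in both urea compounds the number lands near the same place. A downward step in this assay beyond the scatter is therefore expected. Compound 4 is estimated at 500 nM, range 200 nM to 1300 nM, an expected step of a 2.4-fold lower number from compound 2 to compound 4 (0.38 log units; beyond the scatter).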

Compound 4, half-maximal inhibitory concentration: 890 nM
Compound 4: the middle estimate sits 1.8-fold (0.25 log units) below what was measured; the range from low to high includes it.
By their numbers in this assay, from the lowest: compounds 3 and 1 (each within the scatter of the next); then compounds 4 and 2 (each within the scatter of the next).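

In this assay, (4-chloro-3-(trifluoromethyl)phenyl)amino in place of 3-(trifluoromethyl)phenyl on the carbonyl carbon gives a 1.3-fold lower number from compound 2 to compound 4 (0.13 log units; within the scatter) and turns the amide into a urea, the only listed step that touches the linker. Amide-to-urea conversion together with this added chlorine therefore brings no change beyond the scatter, something the comparison of compound 2 with compound 1, which differ in the aryl group as well, could not show. No measured information bears on the reason for this result.

Open, from the compounds shown here alone, is whether an amide and a urea carrying an identical aryl group would differ, since this step changes the linker and the aryl substitution together. Also open, going by these compounds, is how a thiourea or a sulfonamide linker in this assay would compare with the urea and amide.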